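Working notes: from compound 2 to compound 4

The source may hold more compounds than are shown below. What is called first, only, known or untested is meant among the compounds shown, and "the series" means these compounds.

Measured so far:
compound 1, `CCCCOc1ccc(-c2c(C)[nH]c(=O)n2C)cc1`, 5100 nM
compound 2, `CCCCOc1ccc(-c2c(C)[nH]c(=O)n2C2CCCCC2)cc1`, 13900 nM
compound 3, `Cc1[nH]c(=O)n(C)c1-c1ccc(-c2ccccc2)cc1`, 6300 nM

All three have been run in a functional assay on brain (Rattus norvegicus, strain Wistar) for inhibition; a higher number here means a weaker inhibitor, a lower number a stronger inhibitor. Compound 2 carries the highest number of the three; compound 3 is nearest to it and compound 1 furthest, both gaps beyond the scatter. The step from compound 1 to compound 2, cyclohexyl in place of methyl on an aromatic nitrogen, is a modest one: a 2.7-fold higher number from compound 1 to compound 2 (0.44 log units; beyond the scatter).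

Compound 4, `Cc1[nH]c(=O)n(C2CCCCC2)c1-c1ccc(OCc2ccccc2)cc1`, has not yet been measured. It differs from compound 2 in one place: phenyl in place of propyl on a saturated chain carbon bound to an oxygen on an aromatic ring.

Among the measured compounds shown here, only one measured step touches the same end of the molecule. From compound 1 to compound 3, phenyl replaces butoxy on an aromatic carbon, and the number moves a 1.2-fold higher number from compound 1 to compound 3 (0.09 log units; within the scatter), within the scatter. That step exchanges the whole butoxy group rather than extending it to benzyloxy, so it bears on the present change only loosely, yet it is the nearest guide and points to no step beyond the scatter. The cyclohexyl on the aromatic nitrogen is unchanged between compound 2 and compound 4, so the step from compound 1 to compound 2 does not bear here.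

Compound 4 is therefore estimated at 12000 nM, with a range of 5000 nM to 30000 nM. This estimate means an expected step of a 1.2-fold lower number from compound 2 to compound 4 (0.06 log units; within the scatter), within the scatter.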

Compound 4, half-maximal inhibitory concentration: 8300 nM
For compound 4 the middle estimate is 1.4-fold (0.16 log units) above the measured one; low and high end bracket the measured number.
By their numbers in this assay, from the lowest: compounds 1, 3, 4 and 2 (each within the scatter of the next, the first and the last beyond it).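

In this assay, among the compounds shown here, the change from butoxy to benzyloxy gives a 1.7-fold lower number from compound 2 to compound 4 (0.22 log units; within the scatter) and so shows, for the first time, a phenyl carried on the chain while the oxygen on the aromatic ring stays in place, with cyclohexyl on the aromatic nitrogen. The earlier change at this end removed that oxygen along with the rest of the butoxy group and, with methyl on the aromatic nitrogen, gave a 1.2-fold higher number from compound 1 to compound 3 (0.09 log units; within the scatter) in the same assay, so the two different changes at this end of the shared core both stay within the scatter. No measurement in hand bears on the reason for the result with compound 4.

The compounds shown leave open whether benzyloxy behaves the same way with methyl on the aromatic nitrogen, as that pairing does not appear among them. They also give no reading of what an amine, a carboxylic acid or a longer chain between the oxygen and the phenyl would do at this end of the molecule, so the tolerance seen here is established only for butoxy, benzyloxy and phenyl.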